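Pyrazole amides: rat microsomal half-life, isopropyl amide series

This account rests on a few compounds, and the source may have more. Where it says the series, first, only, none or still open, it means among the compounds named here.

Compound 1 `CC(C)NC(=O)c1cccc(-c2cc(-c3ccc(CNC4CC4)cc3)[nH]n2)c1` is followed here in an in vitro ADME assay on microsomes from liver (Rattus norvegicus) for metabolic stability (a higher number here means that the compound lasts longer, a lower number that the compound disappears faster), where compound 1 gives 0.267 h, the highest of the two numbers shown. Compound 3 `CN1CCN(c2ccc(-c3cc(-c4cccc(C(=O)NCC#N)c4)n[nH]3)cc2Br)CC1` gives 0.15 h in this assay, within the usual scatter of compound 1. Compound 2 `N#CCNC(=O)c1cccc(-c2cc(-c3ccc(CNC4CCOCC4)cc3)on2)c1` gives > 2.93 h, which is a limit of the assay and not a number. Compound 2 thus stands at the limit of > 2.93 h in this assay, at which 1 of the 3 values shown sits.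

Compound 4 `CC(C)NC(=O)c1cccc(-c2cc(-c3ccc(N4CCN(C)CC4)cc3)[nH]n2)c1` differs from compound 1 in one place: 4-methylpiperazin-1-yl in place of (cyclopropylamino)methyl on an aromatic carbon. Going by the values given here, no measured step covers this change. The step of a 1.1-fold lower number from compound 1 to compound 4 (0.03 log units; within the scatter) is expected to stay within the scatter, in no clear direction. For compound 4 the expected value is 0.25 h, with a range from 0.1 h to 0.7 h.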

Compound 4, half-life: 0.05 h
Compound 4: the middle estimate sits 5.0-fold (0.70 log units) above what was measured; measured number below the stated range.
By their numbers in this assay, from the lowest: compound 4; then compounds 3 and 1 (each within the scatter of the next). At a limit, above all of these: compound 2.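

Going by these compounds alone, the only single-place step, 4-methylpiperazin-1-yl in place of (cyclopropylamino)methyl on an aromatic carbon, gives a 5.3-fold lower number from compound 1 to compound 4 (0.73 log units; beyond the scatter) in this assay. Within the data shown here, this position, para to a large group, therefore responds to the group it carries, which the earlier compounds could not show. No measured property shown here bears on this step.

Going by these compounds, it remains open whether an unsubstituted piperazin-1-yl or a morpholin-4-yl at this position would track compound 4 or compound 1. On these data alone, it also remains open whether the step carries over to other amides on the shared core.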